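Swapping the aromatic ring on the double-bonded chain carbon

The source may hold more compounds than are shown below. What is called first, only, known or untested is meant among the compounds shown, and "the series" means these compounds.

Compound 3 `COc1ccc(CNC(=O)/C(C#N)=C/c2ccoc2)cc1` gives 8000 nM in a functional assay on MIA cells (Homo sapiens) for inhibition, read by MTT assay, with a stated time of 72 h (on this read-out higher numbers stand for weaker inhibition of growth and lower numbers for stronger inhibition of growth), the lowest of the two numbers shown; its nearest neighbour is compound 2 `COc1ccc(CNC(=O)/C(C#N)=C/c2ccc(C)o2)cc1`, which gives 51000 nM, and the step of a 6.4-fold lower number from compound 2 to compound 3 (0.80 log units; beyond the scatter). Compound 1 `COc1ccc(CNC(=O)/C(C#N)=C/c2ccc[nH]2)cc1` reaches only the assay limit > 50000 nM. Compound 4 `COc1ccc(CNC(=O)/C(C#N)=C/c2ccc(C)cc2)cc1` differs from compound 3 by 4-methylphenyl in place of furan-3-yl on a double-bonded chain carbon bound to a double-bonded chain carbon. Among the compounds with values here, the steps of a 6.4-fold lower number from compound 2 to compound 3 (0.80 log units; beyond the scatter) and an at least 6.2-fold lower number from compound 1 to compound 3 (0.79 log units; beyond the scatter) both concern this same position and both moved toward furan-3-yl, but no measured step compares furan-3-yl with a six-membered carbon ring, so the direction of the new step is uncertain and the position appears sensitive. Compound 4 is therefore expected to give a somewhat higher number, estimated at 15000 nM with a range from 4000 nM to 60000 nM. This would mean an expected step of a 1.9-fold higher number from compound 3 to compound 4 (0.27 log units; within the scatter).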

Compound 4, concentration for 50% growth inhibition: 38000 nM
Compound 4: middle estimate off by 2.5-fold (0.40 log units), on the low side; the measured number falls inside the stated range.
By their numbers in this assay, from the lowest: compound 3; then compounds 4 and 2 (each within the scatter of the next).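

In this assay, the change from furan-3-yl to 4-methylphenyl gives a 4.8-fold higher number from compound 3 to compound 4 (0.68 log units; beyond the scatter), showing that this six-membered carbon ring does not keep the number of furan-3-yl. Against the other two rings the same group gives a 1.3-fold lower number from compound 2 to compound 4 (0.13 log units; within the scatter) and an at least 1.3-fold lower number from compound 1 to compound 4 (0.11 log units; that floor lies within the scatter), so among these compounds only furan-3-yl stands apart. Compound 1 sits at a limit of the assay, so its step is only a floor: the limit of > 50000 nM in this assay, at which 1 of the 4 values shown sits.

As far as these compounds go, it remains open how an unsubstituted phenyl, an unsubstituted furan-2-yl or a thiophen-3-yl would read at this place. Such groups would separate the effect of the methyl from that of the ring itself.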